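Arylsulfonyl series: bromo in place of fluoro

The compounds below may be only part of what the source reports. "The series", "measured", "known", "first", "only" and "open" are said of these compounds alone.

- compound 1 `O=C1/C(=C/c2ccncc2)CNC/C1=C\c1ccccc1C(F)(F)F`: 4900 nM
- compound 2 `O=C1/C(=C/c2ccncc2)CN(S(=O)(=O)c2ccc(C(F)(F)F)cc2)C/C1=C\c1ccccc1C(F)(F)F`: 4680 nM
- compound 3 `O=C1/C(=C/c2ccncc2)CN(S(=O)(=O)c2ccc(F)cc2)C/C1=C\c1ccccc1C(F)(F)F`: 7700 nM

In a functional assay on QGY-7703 cells (Homo sapiens) for cytotoxicity, read by MTT assay, with a stated time of 24 h (on this read-out lower numbers stand for stronger inhibition and higher numbers for weaker inhibition), compound 3 gives 7700 nM, which lies within the scatter of both other compounds. The next change leads to compound 4 `O=C1/C(=C/c2ccncc2)CN(S(=O)(=O)c2ccc(Br)cc2)C/C1=C\c1ccccc1C(F)(F)F`, with bromo in place of fluoro on an aromatic carbon. The closest measured change swaps the group on an aromatic carbon, fluoro in place of trifluoromethyl: a 1.6-fold higher number from compound 2 to compound 3 (0.22 log units; within the scatter). Placing the (4-fluorophenyl)sulfonyl group on the ring nitrogen gave a 1.6-fold higher number from compound 1 to compound 3 (0.20 log units; within the scatter). Among the measured compounds shown here, neither step exceeds the scatter, and no bromo compound has been measured, so no step beyond the scatter is expected in this assay. The expected step is a 1.4-fold lower number from compound 3 to compound 4 (0.13 log units; within the scatter). Compound 4 is estimated at 5700 nM, with an expected range of 3000 nM to 10500 nM.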

Compound 4, half-maximal inhibitory concentration: 7060 nM
Beside the measured number, compound 4's estimate is 1.2-fold (0.09 log units) below it, within the range that was stated.
By their numbers in this assay, from the lowest: compounds 2, 1, 4 and 3 (each within the scatter of the next).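

With bromo, this aromatic carbon has carried three different groups in this assay without any separating: a 1.1-fold lower number from compound 3 to compound 4 (0.04 log units; within the scatter) and a 1.5-fold higher number from compound 2 to compound 4 (0.18 log units; within the scatter) both lie within the scatter. The (4-bromophenyl)sulfonyl group on the ring nitrogen also gives a 1.4-fold higher number from compound 1 to compound 4 (0.16 log units; within the scatter) and so stays within the scatter of the unsubstituted amine. No measurement of any property of these groups accompanies this result.

Open, going by these compounds, is whether an amine or a carboxylic acid on this aromatic carbon would also stay within the scatter. Also open, on these data alone, is whether an acetyl group on the ring nitrogen would do the same.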